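Pyrimidinyl in Place of Hydroxyphenyl: Expected Solubility

This account rests on a few compounds, and the source may have more. Where it says the series, first, only, none or still open, it means among the compounds named here.

Compound 2 `Cc1cc(NCc2ccccn2)n2ncc(-c3ccc(O)cc3)c2n1` has been measured in a physicochemical assay for solubility, read by HPLC, using the shake flask method, measured as kinetic solubility, with a stated time of 2 h, at pH 7.4 (a higher number here means a more soluble compound, a lower number a less soluble compound), where compound 2 gives 10900 nM. Among the values shown, this is the only number. Compound 1 `Cc1cc(NCc2ccccn2)n2ncc(-c3ccc(C#N)cc3)c2n1` sits at a limit of this assay; in this assay compound 1 gives < 5000 nM. Among the compounds with values here, the single measured step, an at least 2.1-fold higher number from compound 1 to compound 2 (0.33 log units; beyond the scatter), rests on hydroxy replacing cyano and is stated as at least that size because of the limit of < 5000 nM in this assay, at which 1 of the 2 values shown sits.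

Compound 3 `Cc1cc(NCc2ccccn2)n2ncc(-c3cncnc3)c2n1` is not yet measured in this assay. It differs from compound 2 by pyrimidin-5-yl in place of 4-hydroxyphenyl on an aromatic carbon. Within the data shown here, no measured step concerns this exchange; the step from compound 1 to compound 2 shows only that a change at this place can move the value beyond the scatter. Compound 3 is therefore expected to lie close to compound 2, and the expected step is a 1.3-fold higher number from compound 2 to compound 3 (0.11 log units; within the scatter). The estimated value for compound 3 is 14000 nM, between 5000 nM and 45000 nM.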

Compound 3, solubility: 111000 nM
The estimate for compound 3 lay 7.9-fold (0.90 log units) below the measured number; measured number above the stated range.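

In this assay, pyrimidin-5-yl in place of 4-hydroxyphenyl gives a 10-fold higher number from compound 2 to compound 3 (1.01 log units; beyond the scatter), so this aromatic carbon of the five-membered ring can carry a large step, not only the smaller one seen earlier. Set against 4-cyanophenyl, the same group gives an at least 22-fold higher number from compound 1 to compound 3 (1.34 log units; beyond the scatter). Compound 1 gives a limit and not a number, and this step is stated as a minimum size because of it: the limit of < 5000 nM in this assay, at which 1 of the 3 values shown sits.

The compounds shown do not separate the two ring nitrogen atoms that enter from the hydroxy group that leaves, since both differences come in one exchange. Going by these compounds, whether a pyridinyl group with one ring nitrogen, or a phenyl ring carrying an amine, at this place gives a number nearer that of compound 2 or that of compound 3 remains open.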